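N-Alkyl extension in the isothiazole ether series

This account rests on a few compounds, and the source may have more. Where it says the series, first, only, none or still open, it means among the compounds named here.

Measured compounds:
compound 1 `CC(C)c1snc(-c2c(Cl)cccc2Cl)c1COc1ccc(/C=C/c2cccc(C(=O)O)c2)c(Cl)c1` 570 nM
compound 2 `CN(Cc1ccc(C(=O)O)cc1)c1ccc(OCc2c(-c3c(Cl)cccc3Cl)nsc2C2CC2)cc1C(F)(F)F` 410 nM
compound 3 `CC(C)c1snc(-c2c(Cl)cccc2Cl)c1COc1ccc(N(C)Cc2ccc(C(=O)O)cc2)c(C(F)(F)F)n1` 350 nM

In an assay on HEK293T cells for agonist activity at Bile acid receptor (Homo sapiens), read by a luciferase reporter and fluorescence (a higher number here means that more compound is needed for the effect, a lower number that less compound is needed), compound 3 gives 350 nM, the lowest of the three numbers. Compound 2 gives 410 nM and compound 1 gives 570 nM; both differences to compound 3 are within the scatter, so no order among the three is claimed.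

Compound 4 `CCN(Cc1ccc(C(=O)O)cc1)c1ccc(OCc2c(-c3c(Cl)cccc3Cl)nsc2C(C)C)nc1C(F)(F)F` has not been measured. It differs from compound 3 in one place: methyl in place of hydrogen on a saturated chain carbon bound to a nitrogen on an aromatic ring, which reads as methyl to ethyl when the change is cut one bond further out. Within the data shown here, no pair of measured compounds shows this change, so there is no step to lean on. A single carbon added to the chain on the nitrogen is expected to leave this assay nearly unchanged, in either direction, with no step beyond the scatter foreseen. The step from compound 3 to compound 4 is estimated as a 1.1-fold higher number from compound 3 to compound 4 (0.04 log units; within the scatter). Compound 4 is therefore expected to give about 380 nM, with a range from 150 nM to 950 nM.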

Compound 4, half-maximal effective concentration: 2160 nM
Estimate against measurement, compound 4: 5.7-fold (0.75 log units) below, outside the stated range (above it).
By their numbers in this assay, from the lowest: compounds 3, 2 and 1 (each within the scatter of the next); then compound 4.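

In this assay, among these compounds, methyl to ethyl on the nitrogen gives a 6.2-fold higher number from compound 3 to compound 4 (0.79 log units; beyond the scatter), the first step that can be read at a single place and one that lies beyond the scatter. Among the compounds shown here, the opening set held no pair differing in one place, so it said nothing about this position; the chain on this nitrogen now proves to be a place where even this small addition moves the number. No measurement at hand accounts for the rise.

As far as these compounds go, whether a propyl chain or a 2-hydroxyethyl group on the same nitrogen would raise the number further or bring it back stays open. Also open, from the compounds shown here alone, is whether a bare hydrogen on that nitrogen would give a lower number than compound 3 at 350 nM.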